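A few compounds are considered here, and "the series" means these few. Any claim that something is new, unique, unknown or untested is made for them only; others in the source may bear on it.

Measured compounds:
compound 1, `C=Cc1nc2ccccc2n1C`, 9500 nM;
compound 2, `Cn1c(I)nc2ccccc21`, 17500 nM;
compound 3, `Ic1nc2ccccc2o1`, only a limit.

In a functional assay on HCT-116 cells (Homo sapiens) for cytotoxicity, with a stated time of 3 days (on this read-out higher numbers stand for weaker inhibition and lower numbers for stronger inhibition), compound 1 gives 9500 nM and compound 2 gives 17500 nM. The step between them, a 1.8-fold lower number from compound 2 to compound 1 (0.27 log units; within the scatter), is vinyl in place of iodo on an aromatic carbon. For compound 3 the value of > 40000 nM is a limit of this assay and not a number, at the limit of > 40000 nM in this assay, at which 1 of the 3 values shown sits. How the core of compound 3 differs from the core of compound 2 is not broken down here. Compound 4, `C=Cc1nc2ccccc2o1`, is not yet measured; it arises from compound 3 by vinyl in place of iodo on an aromatic carbon, the same kind of change as from compound 2 to compound 1, though the place differs: in compound 3 the carbon lies next to the ring nitrogen and next to the ring oxygen, in compound 2 between two ring nitrogen atoms, next to the ring atom that bears a methyl group. Since the earlier step stayed within the scatter, compound 4 is expected to give 40000 nM, between 15000 nM and 100000 nM, a step of a number no higher from compound 3 to compound 4 (the limit leaves the size open).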

Compound 4, half-maximal inhibitory concentration: > 40000 nM
Compound 4: only a limit was reported; the forecaster's own chance of this, stated with the estimate: 60%; the middle value lies on the limit itself.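

In this assay compound 4 gives > 40000 nM, a limit and not a number, and compound 3 also stands at a limit, so no step between compound 3 and compound 4 can be read: the limit of > 40000 nM in this assay, at which 2 of the 4 values shown sit.

The compounds shown leave open how far vinyl in place of iodo on an aromatic carbon moves the number on the core of compound 3.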